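Sulfur in place of selenium on the quinoline-like core

This account rests on a few compounds, and the source may have more. Where it says the series, first, only, none or still open, it means among the compounds named here.

Measured so far:
compound 1 `OCC#CCSc1cnc2ccccc2c1SCC#CCO` — 42.2 ug/mL
compound 2 `C#CCSc1cnc2ccccc2c1[Se]CC#CCBr` — 4.2 ug/mL
compound 3 `C#CCSc1cnc2ccccc2c1[Se]CC#CCO` — 3.6 ug/mL

The read-out throughout is a functional assay on B16 cells (Mus musculus) for cytotoxicity, read by sulforhodamine B assay, with a stated time of 72 h; on this read-out higher numbers stand for weaker inhibition and lower numbers for stronger inhibition. Among the three numbers compound 3 has the lowest; compound 2 sits nearest, within the scatter, while compound 1 is furthest, beyond it. Among the compounds with values here, the one single-point step available, a 1.2-fold lower number from compound 2 to compound 3 (0.07 log units; within the scatter), concerns the chain end and stays within the scatter. Compound 4 `C#CCSc1cnc2ccccc2c1SCC#CCO` differs from compound 3 by a group of 6 heavy atoms (4 carbon, 1 oxygen, 1 sulfur; no ring) in place of a group of 6 heavy atoms (4 carbon, 1 oxygen, 1 selenium; no ring), on an aromatic carbon. Within the data shown here, no measured step isolates this exchange. Compound 1, which carries sulfur on both sides of the core, gives 42.2 ug/mL in this assay, and compound 3 gives 3.6 ug/mL, but these two also differ at the other chain, so the selenium-to-sulfur part cannot be separated from the rest. The expectation for compound 4 is therefore a move toward a higher number, of uncertain size, expressed as a 3.3-fold higher number from compound 3 to compound 4 (0.52 log units; beyond the scatter). Compound 4 is estimated at 12 ug/mL, with a range from 4 ug/mL to 40 ug/mL.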

Compound 4, concentration for 50% inhibition: 54.7 ug/mL
Estimate against measurement, compound 4: 4.6-fold (0.66 log units) below; the whole stated range lies below it.
By their numbers in this assay, from the lowest: compounds 3 and 2 (each within the scatter of the next); then compounds 1 and 4 (each within the scatter of the next).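

In this assay, replacing the selenium-linked group with the sulfur-linked group on this aromatic carbon, with the hydroxy chain end unchanged, gives a 15-fold higher number from compound 3 to compound 4 (1.18 log units; beyond the scatter), so this single atom exchange alone accounts for a large change. The step of a 13-fold higher number from compound 2 to compound 4 (1.11 log units; beyond the scatter), which also replaces bromo with hydroxy at the chain end, is likewise large. With sulfur at this position, the other chain's end shows no effect beyond the scatter, as a 1.3-fold higher number from compound 1 to compound 4 (0.11 log units; within the scatter) indicates.

No available evidence explains why the selenium-to-sulfur exchange has so large an effect. The compounds shown also leave open how an oxygen or amine link at this position would compare, and whether selenium on the propargylsulfanyl side would change the number too.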